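The compounds below may be only part of what the source reports. "The series", "measured", "known", "first", "only" and "open" are said of these compounds alone.

Compound 1, `Nc1ccccc1NC(=O)c1ccc(CSC(=S)N2CCN(Cc3ccccn3)CC2)cc1`, belongs to a small set of benzamides that carry a dithiocarbamate arm on the shared core. In a functional assay on A-375 cells (Homo sapiens) for antiproliferative activity, read by CCK-8 assay, with a stated time of 72 h, tested at 2 uM (on this read-out higher numbers stand for a stronger effect at the one concentration tested and lower numbers for a weaker effect), compound 1 gives 20.7%, the lowest of the three numbers recorded. For the measured compounds named here, compound 2, `CC1CCCCN1C(=S)SCc1ccc(C(=O)Nc2ccccc2N)cc1`, gives 42.5% in this assay, and compound 3, `CN(Cc1cccnc1)C(=S)SCc1ccc(C(=O)Nc2ccccc2N)cc1`, gives 39.4%; the one measured step, a number 3.1 percentage points lower from compound 2 to compound 3 (within the scatter), changes the amine on the thiocarbonyl carbon and stays within the scatter. Compound 4, `Nc1ccccc1NC(=O)c1ccc(CSC(=S)N2CCN(Cc3ccncc3)CC2)cc1`, has not yet been measured. It differs from compound 1 by pyridin-4-yl in place of pyridin-2-yl on a saturated chain carbon bound to an amine nitrogen in a ring. Going by the values given here, no measured step touches this position: the step from compound 2 to compound 3 concerns a different part of the molecule, and the gap from compound 1 up to compound 3 or compound 2 comes with a change of the whole amine, not of the pyridine attachment. With nothing shown to move the number, the expected step of a number 1.3 percentage points higher from compound 1 to compound 4 (within the scatter) is none beyond the scatter. Compound 4 is therefore estimated at 22%, with a range from 10% to 36%.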

Compound 4, a percentage reported as inhibition, at one concentration (the size of the read-out at that concentration, not a potency): 33.1%
For compound 4 the middle estimate is 11.1 percentage points below the measured one; the range from low to high includes it.
By their numbers in this assay, from the lowest: compound 1; then compounds 4, 3 and 2 (each within the scatter of the next).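

At this position the attachment of the pyridine matters: on a saturated chain carbon bound to an amine nitrogen in a ring, pyridin-4-yl in place of pyridin-2-yl comes with a number 12.4 percentage points higher from compound 1 to compound 4 (beyond the scatter) in this assay. For the compounds shown here, compound 1 and compound 4 hold the same atoms, joined differently, and this is the first single-place step in the set to pass the scatter, which the earlier step among the amines on the thiocarbonyl carbon did not do. Nothing measured accounts for this difference.

On these data alone, it remains open whether a plain phenyl group at this place would stand nearer to compound 1 or to compound 4. Also open, as far as these compounds go, is whether a longer chain carrying the pyridin-4-yl would keep the higher number.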